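The source may hold more compounds than are shown below. What is called first, only, known or untested is meant among the compounds shown, and "the series" means these compounds.

Measured compounds: compound 1 `CCCCNc1nc(N)nc2cc(OC)ccc12`, compound 2 `CCCCNc1nc(N)nc2cc(CO)ccc12`, compound 3 `CCCCNc1nc(N)nc2cc(C(=O)N(C)C)ccc12`.

In an ADME assay on HEK293 cells for agonist activity at Toll-like receptor 8 (Homo sapiens), read by a luciferase reporter, with a stated time of 6 h (a lower number here means that less compound is needed, a higher number that more compound is needed for the effect), compound 1 gives 0.3 uM, compound 2 gives 0.1 uM, and compound 3 gives 0.5 uM. Compound 1 thus stands second highest of the three numbers, with a 1.7-fold higher number from compound 1 to compound 3 (0.22 log units; within the scatter) and a 3.0-fold lower number from compound 1 to compound 2 (0.48 log units; beyond the scatter). Compound 4 `CCCCNc1nc(N)nc2cc(OC)c(OC)cc12` differs from compound 1 by methoxy in place of hydrogen on an aromatic carbon. Within the data shown here, none of the measured steps adds a group to an unsubstituted aromatic carbon; each replaces the methoxy with another group, so they speak only indirectly to this change. Because those steps range from a 5.0-fold higher number from compound 2 to compound 3 (0.70 log units; beyond the scatter) to a 1.7-fold higher number from compound 1 to compound 3 (0.22 log units; within the scatter), compound 4 is expected to move little in this assay, a step of no change at the digits printed from compound 1 to compound 4 (within the scatter) or none beyond the scatter. Compound 4 is therefore estimated at 0.3 uM, within 0.1 uM to 1 uM.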

Compound 4, minimum effective concentration: 1.1 uM
The estimate for compound 4 lay 3.7-fold (0.56 log units) below the measured number; the whole stated range lies below it.
By their numbers in this assay, from the lowest: compound 2; then compounds 1 and 3 (each within the scatter of the next); then compound 4.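

Methoxy in place of hydrogen, on the aromatic carbon ortho to a methoxy group, gives a 3.7-fold higher number from compound 1 to compound 4 (0.56 log units; beyond the scatter) in this assay, so this carbon is not indifferent to substitution. Compounds 1, 2 and 3 all carry hydrogen here and could not show this, since their steps only exchange the group at the other carbon. Nothing measured on these compounds accounts for the rise.

From the compounds shown here alone, whether fluorine, an amine or a longer ether such as ethoxy at this carbon would raise the number similarly remains open. So does whether the step would recur with the hydroxymethyl of compound 2 in place of the existing methoxy.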